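Removing the tosylamino group from a T-type channel inhibitor

The source may report more compounds than this note shows. Statements on the series, on what has been measured and on what is new or still open speak of the compounds shown alone.

Measured compounds:
compound 1 `Cc1ccc(S(=O)(=O)Nc2ccc(CNC(=O)CC3c4ccccc4N=C(N4CCCCC4)N3c3ccccc3)cc2)cc1` gives 170 nM
compound 2 `CC(C)(C)OC(=O)NCCCCCNC1=Nc2ccccc2C(CC(=O)NCc2ccccc2)N1c1ccc(-c2ccccc2)cc1` gives 160 nM
compound 3 `NCCCCCN1C(Nc2ccc(-c3ccccc3)cc2)=Nc2ccccc2C1CC(=O)NCc1ccccc1` gives 140 nM

All three values come from an assay on HEK293 cells for inhibition of Voltage-dependent T-type calcium channel subunit alpha-1G (Homo sapiens); a lower number here means a stronger inhibitor, a higher number a weaker inhibitor. On the numbers shown, compound 1 stands alongside compound 2 and compound 3: its value differs from each of theirs by less than the usual scatter, so nothing separates the three. Compound 4 `O=C(CC1c2ccccc2N=C(N2CCCCC2)N1c1ccccc1)NCc1ccccc1` has not been measured in this assay. It differs from compound 1 in one place: hydrogen in place of ((4-methylphenyl)sulfonyl)amino on an aromatic carbon. For the measured compounds named here, no pair of measured compounds shows the effect of such a change, so the expectation rests on compound 1 alone. Losing a group of that size is expected to cost some potency, with the step of a 2.4-fold higher number from compound 1 to compound 4 (0.37 log units; beyond the scatter) expected to go beyond the scatter toward a weaker inhibitor. Compound 4 is therefore estimated at 400 nM, within a range of 150 nM to 1200 nM.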

Compound 4, half-maximal inhibitory concentration: 1160 nM
Compound 4: middle estimate off by 2.9-fold (0.46 log units), on the low side; the range from low to high includes it.
By their numbers in this assay, from the lowest: compounds 3, 2 and 1 (each within the scatter of the next); then compound 4.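

In this assay, for the compounds shown here, the loss of the ((4-methylphenyl)sulfonyl)amino group gives a 6.8-fold higher number from compound 1 to compound 4 (0.83 log units; beyond the scatter) as its step, the first change at this place on the aromatic ring that can be read. The group, absent from the other compounds shown, therefore counts for potency on the core of compound 1. Nothing available accounts for the size of this loss. The whole group leaves at once. The step cannot say which part of it matters. Going by these compounds, whether a plain amine or a methylsulfonylamino group at that place would hold the potency remains open.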